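Ring-oxygen aryl variation in a fused tricyclic antiproliferative series

This account rests on a few compounds, and the source may have more. Where it says the series, first, only, none or still open, it means among the compounds named here.

Measured so far:
compound 1, `CCC1=C(O)c2c(oc(-c3ccc(C(F)(F)F)cc3)cc2=O)C(CC)(CC)C1=O`, 35.7 uM
compound 2, `CCC1=C(O)c2c(oc(-c3ccccc3C)cc2=O)C(CC)(CC)C1=O`, 40.9 uM
compound 3, `CCC1=C(O)c2c(oc(-c3ccc(OC)c(C)c3C)cc2=O)C(CC)(CC)C1=O`, 5.43 uM

In a functional assay on KB cells (Homo sapiens) for antiproliferative activity, read by sulforhodamine B assay, with a stated time of 3 days (on this read-out higher numbers stand for an effect only at larger amounts of compound and lower numbers for an effect already at smaller amounts), compound 2 gives 40.9 uM, the highest of the three numbers. Compound 1 sits within the scatter of it, while compound 3 gives a number well beyond the scatter lower. Compound 4, `CCC1=C(O)c2c(oc(-c3ccc(F)c(C)c3)cc2=O)C(CC)(CC)C1=O`, has not yet been measured. It differs from compound 2 by 4-fluoro-3-methylphenyl in place of 2-methylphenyl on an aromatic carbon. Among the measured compounds shown here, no measured pair shows this exact change, so its size is open; the three compounds together suggest that the aryl group can move the number considerably. Compound 4 is expected to give 20 uM, in the range 5 uM to 60 uM. The estimated step of a 2.0-fold lower number from compound 2 to compound 4 (0.31 log units; beyond the scatter) is expected to be a modest lowering, possibly not beyond the scatter.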

Compound 4, concentration for half-maximal effect: 40.5 uM
For compound 4 the middle estimate is 2.0-fold (0.31 log units) below the measured one, and the stated range covers the measured number.
By their numbers in this assay, from the lowest: compound 3; then compounds 1, 4 and 2 (each within the scatter of the next).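

In this assay, 4-fluoro-3-methylphenyl in place of 2-methylphenyl on the aromatic carbon next to the ring oxygen gives a 1.0-fold lower number from compound 2 to compound 4 (0.00 log units; within the scatter). Among the compounds shown here, this is the first step between two measured compounds that differ in one place, and it shows that this exchange of one aryl group for the other leaves the number unchanged within the scatter. Nothing available explains why the two aryl groups read alike. Still open, as far as these compounds go, is how an aryl group carrying an amine or a carboxylic acid would read at this position. Also open, from the compounds shown here alone, is whether a longer alkyl chain could stand there in place of an aryl group.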